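Thioamidine-type replacement of methoxyphenyl in the benzoxazinone series

This account rests on a few compounds, and the source may have more. Where it says the series, first, only, none or still open, it means among the compounds named here.

Measured so far:
compound 1 `COc1ccc(C2Oc3ccccc3N(CCCCCN3C(C)CCCC3C)C2=O)cc1` — 2.3%
compound 2 `CC1CCCC(C)N1CCCCCN1C(=O)C(c2cccc(C(=N)NN3CCOCC3)c2)Oc2ccccc21` — 58%

In an assay on isolated protein for inhibition of serine protease 1 (Homo sapiens), tested at 100 uM (on this read-out higher numbers stand for more inhibition at the one concentration tested (going by the name of the read-out) and lower numbers for less inhibition), compound 1 gives 2.3%, the lowest of the two numbers at hand. The nearest value is that of compound 2, which in this assay gives 58%, a gap beyond the scatter; as the two structures differ in more than one place, no single step can be read from this pair.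

Compound 3 `CC1CCCC(C)N1CCCCCN1C(=O)C(c2cccc(C(=N)S)c2)Oc2ccccc21` is not yet measured. Relative to compound 1 the change is a group of 9 heavy atoms (7 carbon, 1 nitrogen, 1 sulfur; one six-membered aromatic ring of carbon only) in place of a group of 8 heavy atoms (7 carbon, 1 oxygen; one six-membered aromatic ring of carbon only), on a saturated ring carbon. Within the data shown here, no measured step of this kind exists, so the size of the step in this assay from compound 1 to compound 3 is a matter of judgement only. Since compound 2, whose aromatic ring also carries a group with hydrogen-bond donors, gives 58%, the step of a number 32.7 percentage points higher from compound 1 to compound 3 (beyond the scatter) is expected to be upward and beyond the scatter. For compound 3 the estimate in this assay is 35%, in the range 10% to 65%.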

Compound 3, a percentage reported as inhibition, at one concentration (the size of the read-out at that concentration, not a potency): 5.2%
For compound 3 the middle estimate is 29.8 percentage points above the measured one, and the stated range ends above it.
By their numbers in this assay, from the lowest: compounds 1 and 3 (each within the scatter of the next); then compound 2.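

In this assay, the group carrying the carbon with a double bond to nitrogen and sulfanyl, in place of 4-methoxyphenyl on the saturated ring carbon, gives a number 2.9 percentage points higher from compound 1 to compound 3 (within the scatter); hydrogen-bond donors entering at this position are thus not enough on their own to separate these two compounds. Among these compounds, the single change at the carbon with a double bond to nitrogen, sulfanyl in place of (morpholin-4-yl)amino, gives a number 52.8 percentage points lower from compound 2 to compound 3 (beyond the scatter), so within this pair the inhibition follows the (morpholin-4-yl)amino group and not the aromatic ring with that carbon alone. Nothing at hand accounts for either step.

Open, from the compounds shown here alone, is whether a plain amino group or a piperidin-1-ylamino group on that carbon would keep the inhibition. Also open, going by these compounds, is how much of the step belongs to the morpholine ring itself.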